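Swapping methyl for chloro on the aryl ring of compound 1

The compounds below may be only part of what the source reports. "The series", "measured", "known", "first", "only" and "open" are said of these compounds alone.

Compound 1 `Cc1ccc(-c2n[nH]c3c2CCNCC3)cc1` was tested in an assay on cells for displacement of a labelled ligand from 5-hydroxytryptamine receptor 1E (Homo sapiens), read by scintillation counting, with a stated time of 1.5 h (on this read-out lower numbers stand for stronger inhibition and higher numbers for weaker inhibition), and gave 890 nM, the lowest of the two numbers recorded there. Compound 2 `Cc1ccc(-c2noc3c2CCNCC3)cc1` gave 1790 nM in this assay, a value within the usual scatter of that of compound 1. Compound 3 `Clc1ccc(-c2noc3c2CCNCC3)cc1` reached only the limit of this assay, > 10000 nM, and no number is known for it. Within the data shown here, the one measured step that bears on the change at hand is an at least 5.5-fold higher number from compound 2 to compound 3 (0.74 log units; beyond the scatter), which is the limit of > 10000 nM in this assay, at which 1 of the 3 values shown sits.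

Compound 4 `Clc1ccc(-c2n[nH]c3c2CCNCC3)cc1` differs from compound 1 in a single place: chloro in place of methyl on an aromatic carbon. The step from compound 2 to compound 3 carries the same change on a close analogue of the shared core and was at least modest, in the direction of a higher number, so a rise of similar size is expected here, with a real chance that this assay will again report only its limit. On that basis compound 4 is expected to give 6000 nM, in the range 2000 nM to 20000 nM, an expected step of a 6.7-fold higher number from compound 1 to compound 4 (0.83 log units; beyond the scatter).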

Compound 4, inhibition constant: 1370 nM
For compound 4 the middle estimate is 4.4-fold (0.64 log units) above the measured one, outside the stated range (below it).
By their numbers in this assay, from the lowest: compounds 1, 4 and 2 (each within the scatter of the next). At a limit, above all of these: compound 3.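

On the shared core of compound 1, chloro in place of methyl on an aromatic carbon, para to a large group, leaves this assay essentially unmoved: a 1.5-fold higher number from compound 1 to compound 4 (0.19 log units; within the scatter). The sharp rise seen earlier with this change therefore does not carry over to this core, and the same swap reads differently on the two cores: the same change on two cores in this assay, an at least 5.5-fold higher number (0.74 log units; beyond the scatter) from compound 2 to compound 3 and a 1.5-fold higher number (0.19 log units; within the scatter) from compound 1 to compound 4, at least 3.6-fold (0.55 log units) apart, beyond the scatter of two such steps. Compound 3 stands at a limit of the assay and not at a number: the limit of > 10000 nM in this assay, at which 1 of the 4 values shown sits.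

The compounds shown leave open whether other groups at this place, such as methoxy, a nitrile or an amine, would also stay within the scatter of compound 1 on this core. With one pair on each core, they also leave open whether the difference between the two cores extends beyond chloro and methyl.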